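The source may report more compounds than this note shows. Statements on the series, on what has been measured and on what is new or still open speak of the compounds shown alone.

Among the measured compounds shown here, in a functional assay, read by spectrophotometry, tested at 100 uM (a lower number here means a stronger inhibitor, a higher number a weaker inhibitor), two compounds built on a shared core have numbers so far. Compound 1 (`O=C(/C=C/c1ccc(Cl)cc1)c1cccc(NC(=O)c2cc(-c3ccncc3)n[nH]2)c1`) gives 63900 nM, and compound 2 (`O=C(/C=C/c1ccc([N+](=O)[O-])cc1)c1cccc(NC(=O)c2cc(-c3ccncc3)n[nH]2)c1`) gives 52800 nM. Compound 2 therefore stands level with compound 1. The step between them is a 1.2-fold lower number from compound 1 to compound 2 (0.08 log units; within the scatter), with nitro in place of chloro on an aromatic carbon. Compound 3 (`COc1ccccc1/C=C/C(=O)c1cccc(NC(=O)c2cc(-c3ccncc3)n[nH]2)c1`) has no number yet and differs from compound 2 in one place: 2-methoxyphenyl in place of 4-nitrophenyl on a double-bonded chain carbon bound to a double-bonded chain carbon. For the measured compounds named here, only that single measured step bears on this change, and no measured compound carries a 2-methoxyphenyl group, so the evidence is thin. Going by the values given here, with so small a step as the only guide, no shift beyond the scatter is expected in this assay. The expected step is a 1.0-fold higher number from compound 2 to compound 3 (0.02 log units; within the scatter). For compound 3 the estimated value is 55000 nM, with an expected range of 25000 nM to 100000 nM.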

Compound 3, half-maximal inhibitory concentration: 41700 nM
Estimate against measurement, compound 3: 1.3-fold (0.12 log units) above; the range from low to high includes it.
By their numbers in this assay, from the lowest: compounds 3, 2 and 1 (each within the scatter of the next).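

In this assay, the step is a 1.3-fold lower number from compound 2 to compound 3 (0.10 log units; within the scatter) with 2-methoxyphenyl replacing 4-nitrophenyl, and a 1.5-fold lower number from compound 1 to compound 3 (0.19 log units; within the scatter) with 2-methoxyphenyl replacing 4-chlorophenyl. On a double-bonded chain carbon bound to a double-bonded chain carbon, a third aromatic group, this time carrying methoxy and with its substituent at a different ring position, therefore leaves the number within the scatter of both earlier compounds. Nothing measured here offers an explanation for this flat result.

These compounds change the substituent and its ring position together, so a 4-methoxyphenyl group would be needed to separate those two changes. On these data alone, it also remains open whether an amine or a carboxylic acid on this ring, or any change elsewhere on the shared core, would move the number beyond the scatter.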